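Pyrazole for Pyrrole on the Alkyne of Compound 2

The source may hold more compounds than are shown below. What is called first, only, known or untested is meant among the compounds shown, and "the series" means these compounds.

Measured so far:
Compound 1 `C(#Cc1c[nH]cn1)CN1CCC(Cc2ccccc2)CC1` gives 10 mg/kg in a functional assay on the whole organism for positive allosteric modulation, with Rattus norvegicus as the target; a higher number here means that more compound is needed for the effect, a lower number that less compound is needed.
Compound 2 `C(#Cc1cc[nH]c1)CCN1CCC(Cc2ccccc2)CC1` gives 30 mg/kg in this assay.

Of the two numbers in hand, compound 2 stands at the higher one, meaning more of it is needed for the effect than of compound 1; the gap between the two lies beyond the usual scatter. Going by the values given here, no step between them is counted, since the two structures differ in more than one place.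

Compound 3 `C(#Cc1cn[nH]c1)CCN1CCC(Cc2ccccc2)CC1` keeps the whole frame of compound 2 and changes only the ring at the far end of the triple bond: 1H-pyrazol-4-yl in place of 1H-pyrrol-3-yl on a triple-bonded carbon. Among the compounds with values here, nothing among the measured compounds shows this exchange in isolation, so there is no basis for predicting a shift in either direction. The step from compound 2 is expected to be small, no change at the digits printed from compound 2 to compound 3 (within the scatter), or none beyond the scatter. Compound 3 is therefore estimated at 30 mg/kg, with a range from 10 mg/kg to 100 mg/kg.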

Compound 3, minimum effective dose: 30 mg/kg
Compound 3: middle estimate and measured number agree at the digits printed; measured number inside the range.
By their numbers in this assay, from the lowest: compound 1; then compounds 2 and 3 (each within the scatter of the next).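

In this assay, going by these compounds alone, the exchange of 1H-pyrrol-3-yl for 1H-pyrazol-4-yl on a triple-bonded carbon reads no change at the digits printed from compound 2 to compound 3 (within the scatter) and gives the first comparison here in which only one place differs. This position therefore accepts a second ring nitrogen, which adds a hydrogen-bond acceptor by count and leaves the donor count unchanged, with no shift that can be told from the scatter. Nothing available explains this result.

From the compounds shown here alone, both rings compared here are five-membered and carry a hydrogen on a ring nitrogen, so it remains open how a pyridine ring or a 1-methylpyrazole would fare at the end of the triple bond. The effect of the chain on the ring nitrogen also remains unresolved, since compound 1 differs from compound 2 and compound 3 in more than one place.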